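From methoxy to hydroxymethyl: an untested step in rats

The source may hold more compounds than are shown below. What is called first, only, known or untested is meant among the compounds shown, and "the series" means these compounds.

Of the compounds shown here, two sharing one core have been measured in a functional assay on the whole organism with Rattus norvegicus as the target; on this read-out higher numbers stand for an effect only at larger amounts of compound and lower numbers for an effect already at smaller amounts. There, compound 1 `CCOCCOC(=O)C(=O)Nc1nc(-c2cc(OC)no2)cs1` gives 11 mg/kg, and compound 2 `COc1cc(-c2csc(NC(=O)C(=O)O)n2)on1` gives 8 mg/kg. Among the compounds with values here, the one measured step, a 1.4-fold lower number from compound 1 to compound 2 (0.14 log units; within the scatter), puts hydrogen in place of 2-ethoxyethyl. The two compounds therefore stand level on these numbers.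

Compound 3 `O=C(O)C(=O)Nc1nc(-c2cc(CO)no2)cs1` keeps that hydrogen and differs from compound 2 at another place: hydroxymethyl in place of methoxy on an aromatic carbon. This is hydroxymethyl in place of methoxy on an aromatic carbon of a five-membered aromatic ring with 1 nitrogen and 1 oxygen. The two structures hold the same atoms, joined differently.

Within the data shown here, the measured step lies elsewhere in the molecule and bears on this change only indirectly, and no measured pair varies this group. The data therefore give no ground for a clear shift in this assay, and the starting point remains compound 2 at 8 mg/kg. The expected size is small, a 1.3-fold higher number from compound 2 to compound 3 (0.10 log units; within the scatter), which means no step beyond the scatter is expected, though with modest confidence. For compound 3, the estimated value is 10 mg/kg, with an expected range from 3 mg/kg to 30 mg/kg.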

Compound 3, dose for half-maximal effect: 0.7 mg/kg
Estimate against measurement, compound 3: 14-fold (1.15 log units) above, outside the stated range (below it).
By their numbers in this assay, from the lowest: compound 3; then compounds 2 and 1 (each within the scatter of the next).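

The earlier compounds shown here varied only the other end of the molecule, where 2-ethoxyethyl gave way to hydrogen on an oxygen next to a carbonyl group, and that step stayed within the scatter (a 1.4-fold lower number from compound 1 to compound 2 (0.14 log units; within the scatter)). The aromatic carbon next to the ring nitrogen proves far more responsive in this assay, where hydroxymethyl in place of methoxy gives a large step (an 11-fold lower number from compound 2 to compound 3 (1.06 log units; beyond the scatter)), even though compound 2 and compound 3 hold the same atoms and the counted difference is 1 hydrogen-bond donor for hydroxymethyl against 0 for methoxy, with the same number of heavy atoms and hydrogen-bond acceptors. Nothing measured here explains this step, and the donor count remains only a recorded difference.

The compounds shown leave open whether the step depends on the hydroxyl group itself or on its placement, a question that aminomethyl, methyl or a longer hydroxyethyl chain on the same carbon could help to separate. On these data alone, it also remains open whether hydroxymethyl would give a step of similar size with 2-ethoxyethyl on the oxygen next to a carbonyl group.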